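Methoxy for Bromo in the Propyl Amide Series

This account rests on a few compounds, and the source may have more. Where it says the series, first, only, none or still open, it means among the compounds named here.

Three compounds were measured in a functional assay on A549 cells (Homo sapiens) for antiproliferative activity, read by MTT assay, with a stated time of 72 h; a lower number here means a stronger inhibitor, a higher number a weaker inhibitor:

compound 1, `CNC(=O)c1cc(Oc2ccc(NC(=O)c3cc4cccnc4n(-c4ccc(Br)cc4)c3=O)cc2)ccn1`, 1050 nM
compound 2, `CNC(=O)c1cc(Oc2ccc(NC(=O)c3cc4cccnc4n(-c4ccc(OC)cc4)c3=O)cc2)ccn1`, 3110 nM
compound 3, `CCCNC(=O)c1cc(Oc2ccc(NC(=O)c3cc4cccnc4n(-c4ccc(Br)cc4)c3=O)cc2)ccn1`, 150 nM

Compound 1 and compound 2 share a core and differ in one place: methoxy in place of bromo on an aromatic carbon. That change gave a 3.0-fold higher number from compound 1 to compound 2 (0.47 log units; beyond the scatter). Compound 3 differs from compound 1 in a different place: ethyl in place of hydrogen on a saturated chain carbon bound to an amide-type nitrogen. This gave a 7.0-fold lower number from compound 1 to compound 3 (0.85 log units; beyond the scatter), and compound 3 carries the lowest number of the three, with compound 2 furthest from it.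

Compound 4, `CCCNC(=O)c1cc(Oc2ccc(NC(=O)c3cc4cccnc4n(-c4ccc(OC)cc4)c3=O)cc2)ccn1`, has not yet been measured in this assay. It differs from compound 3 in exactly one place: methoxy in place of bromo on an aromatic carbon. The surroundings of that place are the same, word for word, as for the change from compound 1 to compound 2; the two cores themselves differ as described for compound 1 and compound 3. The change from compound 3 to compound 4 is therefore the same kind of change, seen once before among these compounds, and there it weakened the inhibitor.

For compound 4 the expected step is a 3.0-fold higher number from compound 3 to compound 4 (0.48 log units; beyond the scatter), resting on the step from compound 1 to compound 2 of a 3.0-fold higher number from compound 1 to compound 2 (0.47 log units; beyond the scatter) and on the value of compound 3 of 150 nM. Compound 4 is estimated at 450 nM in this assay, with a range from 200 nM to 1200 nM.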

Compound 4, half-maximal inhibitory concentration: 820 nM
Estimate against measurement, compound 4: 1.8-fold (0.26 log units) below, and the stated range covers the measured number.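

In this assay, methoxy in place of bromo gave a 5.5-fold higher number from compound 3 to compound 4 (0.74 log units; beyond the scatter), so the change raised the number on both cores and the two steps agree: the same change on two cores in this assay, a 3.0-fold higher number (0.47 log units; beyond the scatter) from compound 1 to compound 2 and a 5.5-fold higher number (0.74 log units; beyond the scatter) from compound 3 to compound 4, 1.8-fold (0.27 log units) apart, within the scatter of two such steps
The reverse view of the same square holds as well, since ethyl in place of hydrogen on the amide chain gave a 3.8-fold lower number from compound 2 to compound 4 (0.58 log units; beyond the scatter), and that step also agrees with its earlier counterpart: the same change on two cores in this assay, a 7.0-fold lower number (0.85 log units; beyond the scatter) from compound 1 to compound 3 and a 3.8-fold lower number (0.58 log units; beyond the scatter) from compound 2 to compound 4, 1.8-fold (0.27 log units) apart, within the scatter of two such steps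
Together these results show that, across these four compounds, each change carried over from one core to the other in direction and, within the scatter, in size, but each comparison rests on only one pair of steps in a single cell assay, so they establish neither a general rule for the series nor any reason for the effects.

The compounds shown leave open whether the step from bromo to methoxy would stay the same with a longer chain on the amide, such as butyl, or with a ring there, such as cyclopropyl. They also leave open how other groups in place of bromo, such as chloro, fluoro or an amine, would compare with bromo and methoxy on either core.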